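Fluoro to Chloro on the Pendant Aryl Ring

A few compounds are considered here, and "the series" means these few. Any claim that something is new, unique, unknown or untested is made for them only; others in the source may bear on it.

Compound 1 `COc1cc(-n2cnc3ccc(-c4cccc(N)c4)cc32)cc(OC)c1OC`: 21 nM
Compound 2 `COc1cc(-n2cnc3ccc(-c4cccc(F)c4)cc32)cc(OC)c1OC`: 2490 nM
Compound 3 `COc1cc(-c2ccc3ncn(-c4cc(OC)c(OC)c(OC)c4)c3c2)cc(OC)c1OC`: > 10000 nM

In a functional assay on SGC-7901 cells (Homo sapiens) for antiproliferative activity, read by MTT assay, with a stated time of 72 h (on this read-out higher numbers stand for weaker inhibition and lower numbers for stronger inhibition), compound 1 gives 21 nM while compound 2 gives 2490 nM. Compound 3 is reported only as a limit, > 10000 nM. Compound 2 therefore holds the highest of the two numbers available, and its nearest neighbour is compound 1, the two being separated by a 120-fold higher number from compound 1 to compound 2 (2.07 log units; beyond the scatter), an exchange of fluoro for amino on the pendant ring. Compound 4 `COc1cc(-n2cnc3ccc(-c4ccc(Cl)cc4)cc32)cc(OC)c1OC` is not yet measured; it differs from compound 2 by 4-chlorophenyl in place of 3-fluorophenyl on an aromatic carbon. Among the measured compounds shown here, the only measured step concerns an amino group and does not speak to a halogen-for-halogen exchange, so no large movement is anticipated. For compound 4 the expected step is a 1.2-fold higher number from compound 2 to compound 4 (0.08 log units; within the scatter), giving an estimate of 3000 nM with a range from 800 nM to 12000 nM.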

Compound 4, half-maximal inhibitory concentration: 1270 nM
Compound 4: the middle estimate sits 2.4-fold (0.37 log units) above what was measured; the range from low to high includes it.
By their numbers in this assay, from the lowest: compound 1; then compounds 4 and 2 (each within the scatter of the next). At a limit, above all of these: compound 3.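

With 4-chlorophenyl in place of 3-fluorophenyl, this assay shows a 2.0-fold lower number from compound 2 to compound 4 (0.29 log units; within the scatter), so this position tolerates that halogen exchange without a change beyond the scatter. The large gap to the amino compound also holds with chlorine, at a 60-fold higher number from compound 1 to compound 4 (1.78 log units; beyond the scatter), so it is not confined to the fluoro compound. The data shown offer no measured property that accounts for this gap. Going by these compounds, because the halogen and its place differ together here, their separate contributions remain open. So does what a 3-chlorophenyl, a 4-aminophenyl or a hydroxyl group would give.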